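The source may hold more compounds than are shown below. What is called first, only, known or untested is meant among the compounds shown, and "the series" means these compounds.

Three compounds sharing one core were measured in an assay on HEK293 cells for displacement of a labelled ligand from Melanocortin receptor 4 (Homo sapiens); on this read-out lower numbers stand for stronger inhibition and higher numbers for weaker inhibition. Compound 1 `CCC(=O)N1C[C@@H](C(=O)N2CCN(c3ccc(C)cc3[C@@H](NC(=O)CCN(C)C)C(C)C)CC2)[C@H](c2ccc(Cl)cc2)C1` gives 4.6 nM, compound 2 `CC(=O)N1C[C@@H](C(=O)N2CCN(c3ccc(C)cc3[C@@H](NC(=O)CCN(C)C)C(C)C)CC2)[C@H](c2ccc(Cl)cc2)C1` gives 7.6 nM, and compound 3 `CNCC(=O)N[C@H](c1cc(C)ccc1N1CCN(C(=O)[C@@H]2CN(C3CCOCC3)C[C@H]2c2ccc(Cl)cc2)CC1)C(C)C` gives 2.1 nM. Compound 2 thus carries the highest number of the three; its gap to compound 1 lies within the scatter, while its gap to compound 3 lies beyond it. For the measured compounds named here, the only single-place step known, a 1.7-fold higher number from compound 1 to compound 2 (0.22 log units; within the scatter), was small. Compound 4 `Cc1ccc(N2CCN(C(=O)[C@@H]3CNC[C@H]3c3ccc(Cl)cc3)CC2)c([C@@H](NC(=O)CCN(C)C)C(C)C)c1` differs from compound 2 by hydrogen in place of acetyl on an amine nitrogen in a ring. Going by the values given here, this removes the entire acetyl rather than shortening it, so no measured step matches it directly; a modest change is expected, a 1.6-fold higher number from compound 2 to compound 4 (0.20 log units; within the scatter). Compound 4 is therefore estimated at 12 nM, within a range from 4 nM to 40 nM.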

Compound 4, inhibition constant: 7.2 nM
Compound 4: middle estimate off by 1.7-fold (0.22 log units), on the high side; the range from low to high includes it.
By their numbers in this assay, from the lowest: compound 3; then compounds 1, 4 and 2 (each within the scatter of the next).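

In this assay, replacing the acetyl on the ring nitrogen with hydrogen gives a 1.1-fold lower number from compound 2 to compound 4 (0.02 log units; within the scatter), and replacing the propanoyl gives a 1.6-fold higher number from compound 1 to compound 4 (0.19 log units; within the scatter). Earlier compounds showed only that this acyl chain could be shortened by one carbon; these steps show that, among these compounds, the whole acyl group can go with the number staying within the scatter. Nothing available explains this result. Still open, as far as these compounds go, is whether a benzoyl group or a simple methyl group on this nitrogen would also stay within the scatter.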